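A few compounds are considered here, and "the series" means these few. Any claim that something is new, unique, unknown or untested is made for them only; others in the source may bear on it.

Compound 1 `O=C(Nc1cccc(Cl)c1)c1cc(C(F)(F)F)ccc1OCc1ccccc1` gives 25.1 nM in an assay on Sf9 cells for inhibition of Leucine-rich repeat serine/threonine-protein kinase 2 (Homo sapiens), read by TR-FRET, with stated times of 30 min and 2 h; a higher number here means a weaker inhibitor, a lower number a stronger inhibitor. Compound 2 `C[C@@H]1CN(c2ccc(OCc3ccccc3)c(C(=O)Nc3ccnnc3)c2)C[C@H](C)O1` gives 20 nM in this assay, the lowest of the two numbers, although its gap to compound 1 lies within the scatter. Compound 3 `CN1CC2(CCN(c3ccc(OCc4ccccc4)c(C(=O)Nc4ccnnc4)c3)CC2)C1` differs from compound 2 in a group of 10 heavy atoms (8 carbon, 2 nitrogen; one four-membered non-aromatic ring with 1 hetero atom, one six-membered non-aromatic ring with 1 hetero atom) in place of a group of 8 heavy atoms (6 carbon, 1 nitrogen, 1 oxygen; one six-membered non-aromatic ring with 2 hetero atoms), on an aromatic carbon. Going by the values given here, no step between measured compounds resembles this change, so the account expects a step of a 1.3-fold higher number from compound 2 to compound 3 (0.10 log units; within the scatter), which stays within the scatter and points in no firm direction. Compound 3 is accordingly estimated at 25 nM in this assay, with a range from 8 nM to 80 nM.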

Compound 3, half-maximal inhibitory concentration: 63.1 nM
Compound 3: the middle estimate sits 2.5-fold (0.40 log units) below what was measured; low and high end bracket the measured number.
By their numbers in this assay, from the lowest: compounds 2 and 1 (each within the scatter of the next); then compound 3.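

At the aromatic carbon para to the benzyloxy group and meta to the (pyridazin-4-yl)carbamoyl group, the choice of group matters: in this assay, exchanging the 2,6-dimethylmorpholin-4-yl group for the group with a four-membered and a six-membered non-aromatic ring gives a 3.2-fold higher number from compound 2 to compound 3 (0.50 log units; beyond the scatter). The two groups have equal counts of hydrogen-bond donors and acceptors and no net charge, so these counts do not separate them. Nothing available explains the step.

Still open, as far as these compounds go, is how a plain morpholin-4-yl, a piperidin-1-yl or an open-chain dimethylamino group would read at this position. Also open, from the compounds shown here alone, is whether this step would hold on another core.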